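A few compounds are considered here, and "the series" means these few. Any claim that something is new, unique, unknown or untested is made for them only; others in the source may bear on it.

Measured compounds:
compound 1, `Cc1ccc(C2=NN(c3nc(-c4ccc(F)cc4)cs3)C(c3ccc(F)cc3)C2)s1` — > 500 ug/mL
compound 2, `N#Cc1ccc(-c2csc(N3N=C(c4ccc(Cl)s4)CC3c3ccc(F)cc3)n2)cc1` — > 500 ug/mL
compound 3, `COc1ccc(-c2csc(N3N=C(c4ccc(C)s4)CC3c3ccc(F)cc3)n2)cc1` — 147 ug/mL

All three were tested in an ADME assay on NIH3T3 cells (Mus musculus) for cytotoxicity, read by XTT assay, with a stated time of 24 h; a higher number here means a weaker inhibitor, a lower number a stronger inhibitor. For compound 1 the reported value is a limit of the assay, not a number. For compound 2 the reported value is likewise a limit. Within the data shown here, compound 3 is the only one of the three with an actual number, so it stands alone as the one compound whose cytotoxicity could be pinned down. Among the measured compounds shown here, the one step that can be sized is an at least 3.4-fold lower number from compound 1 to compound 3 (0.53 log units; beyond the scatter), and its size is known only as a lower bound because the limit of > 500 ug/mL in this assay, at which 2 of the 3 values shown sit, marks where compound 1 sits.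

Compound 4 is `Cc1ccc(C2=NN(c3nc(-c4ccc(C#N)cc4)cs3)C(c3ccc(F)cc3)C2)s1`. Relative to compound 3 the change is cyano in place of methoxy on an aromatic carbon. For the measured compounds named here, this step bears on the earlier one in reverse: methoxy gave the only measurable number, while the two compounds without methoxy, compound 1 and compound 2, both sit at a limit, and compound 2 already carries the cyano group that enters here. The expectation is therefore a 2.7-fold higher number from compound 3 to compound 4 (0.43 log units; beyond the scatter), a move back toward the limit in this assay. Compound 4 is expected to give 400 ug/mL, with a range from 150 ug/mL to 500 ug/mL.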

Compound 4, half-maximal inhibitory concentration: 250 ug/mL
Beside the measured number, compound 4's estimate is 1.6-fold (0.20 log units) above it; measured number inside the range.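

In this assay, among these compounds, the change from 4-methoxyphenyl to 4-cyanophenyl is a 1.7-fold higher number from compound 3 to compound 4 (0.23 log units; within the scatter), so at this position the two groups cannot be told apart, and methoxy is no longer the only group here that comes with a measured number. Compound 2 and compound 4 both carry cyano, yet only compound 4 gives a number, and with methyl in place of chloro the step reads an at least 2.0-fold lower number from compound 2 to compound 4 (0.30 log units; that floor lies within the scatter); with cyano in place of fluoro it reads an at least 2.0-fold lower number from compound 1 to compound 4 (0.30 log units; that floor lies within the scatter). Neither of these two steps can be read as a real difference, because each is known only as a floor that does not clear the scatter, set by a limit rather than a number: the limit of > 500 ug/mL in this assay, at which 2 of the 4 values shown sit.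

Still open, as far as these compounds go, is what a group of another kind would do at the same place on this aromatic ring, such as an amine or a carboxylic acid. Also open, from the compounds shown here alone, is how far beyond the limit compound 1 and compound 2 lie, and so whether either truly differs from compound 4.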